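Replacing the benzylamine aryl ring of compound 1

A few compounds are considered here, and "the series" means these few. Any claim that something is new, unique, unknown or untested is made for them only; others in the source may bear on it.

Measured compounds:
- Compound 1, `COc1ccc(CN[C@@H]2CO[C@H](C(c3ccccc3)c3ccccc3)C[C@H]2O)cc1O`, in an assay on striatum for inhibition of sodium-dependent dopamine transporter (Rattus norvegicus); a higher number here means a weaker inhibitor, a lower number a stronger inhibitor: 58.6 nM
- Compound 2, `O[C@@H]1C[C@@H](C(c2ccc(F)cc2)c2ccc(F)cc2)OC[C@H]1NCc1ccc2c(c1)CCO2`, in this assay: 17 nM

Compound 1 holds the higher of the two numbers in this assay; compound 2 gives the lower one, and the gap between them lies beyond the scatter. Compound 3, `COc1ccc(CN[C@@H]2CO[C@H](C(c3ccccc3)c3ccccc3)C[C@H]2O)cn1`, is not yet measured. It differs from compound 1 by 6-methoxypyridin-3-yl in place of 3-hydroxy-4-methoxyphenyl on a saturated chain carbon bound to an amine nitrogen. Among the measured compounds shown here, no pair of measured compounds tracks this change, so the expectation rests on the change alone. The step of a 1.5-fold higher number from compound 1 to compound 3 (0.16 log units; within the scatter) is expected to be small and toward a weaker inhibitor. Compound 3 is therefore expected to give about 85 nM, within a range from 25 nM to 280 nM.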

Compound 3, inhibition constant: 44.1 nM
For compound 3 the middle estimate is 1.9-fold (0.28 log units) above the measured one, within the range that was stated.
By their numbers in this assay, from the lowest: compound 2; then compounds 3 and 1 (each within the scatter of the next).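

In this assay, exchanging the 3-hydroxy-4-methoxyphenyl group for a 6-methoxypyridin-3-yl group gives a 1.3-fold lower number from compound 1 to compound 3 (0.12 log units; within the scatter). At this position, the aryl group can therefore go from 1 hydrogen-bond donor to 0 and take a ring nitrogen without a shift beyond the scatter. No supporting measurement bears on this result. From the compounds shown here alone, it remains open whether the methoxy group on the pyridine ring is needed, or whether an ethoxy group, a trifluoromethyl group or a simple hydrogen there would give a similar number.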